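Chloro in place of methoxy on a fused aromatic ring

A few compounds are considered here, and "the series" means these few. Any claim that something is new, unique, unknown or untested is made for them only; others in the source may bear on it.

Of the compounds shown here, two have been tested so far. Compound 1 `CC(=O)Nc1cccc2c1CCCC2c1c[nH]cn1` gives 5.89 in a functional assay on Urethra for agonist activity at Alpha-1A adrenergic receptor (Oryctolagus cuniculus) (on this read-out lower numbers stand for lower potency and higher numbers for higher potency (the scale is a negative logarithm)), while compound 2 `COc1ccc(NS(C)(=O)=O)c2c1C(c1c[nH]cn1)CCC2` gives 4.81 in this assay, the lower of the two numbers, standing below compound 1 by a gap that lies beyond the usual scatter of the method.

Compound 3 `CS(=O)(=O)Nc1ccc(Cl)c2c1CCCC2c1c[nH]cn1` is the next compound to be measured. It differs from compound 2 in one place: chloro in place of methoxy on an aromatic carbon, the position being para to a methanesulfonamido group, ortho to one fused ring and meta to the other. For the measured compounds named here, no step between measured compounds covers this particular change, so the direction has to be guessed; a modest rise in this assay seems as likely as no change beyond the scatter, because compound 2 with 4.81 sits at the bottom of the range seen. For compound 3 the estimate is 5.4, expected to lie between 4.7 and 6.1, which means an expected step of a number 0.59 log units higher from compound 2 to compound 3 (beyond the scatter).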

Compound 3, negative logarithm of the half-maximal effective concentration: 4.35
Beside the measured number, compound 3's estimate is 1.05 log units above it; measured number outside the range, below it.
By their numbers in this assay, from the lowest: compound 3; then compound 2; then compound 1.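

In this assay, chloro in place of methoxy on this aromatic carbon, para to a methanesulfonamido group, gives a number 0.46 log units lower from compound 2 to compound 3 (beyond the scatter) on the shared core. The position therefore responds to the group it carries, with methoxy giving the higher number of the two, though this rests on a single pair of compounds. Nothing measured here bears on why the number falls with this change.

As far as these compounds go, whether a hydroxyl, an amine or a fluoro on this carbon would stand nearer to methoxy or to chloro remains open. Also open, from the compounds shown here alone, is whether the same exchange would give a step of similar size with a group other than methanesulfonamido at the para position.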